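This account rests on a few compounds, and the source may have more. Where it says the series, first, only, none or still open, it means among the compounds named here.

Measured compounds:
compound 1 `N#Cc1ccc(Nc2nc(Oc3ccnc4ccccc34)nc(N3CCN(c4ccccc4Cl)CC3)n2)cc1C(F)(F)F` gives 92600 nM in a functional assay on DU-145 cells (Homo sapiens) for cytotoxicity, read by sulforhodamine B assay, with a stated time of 48 h; a lower number here means a stronger inhibitor of growth, a higher number a weaker inhibitor of growth
compound 2 `CC1CC(C)CN(c2nc(Nc3ccc(C#N)c(C(F)(F)F)c3)nc(Oc3ccnc4ccccc34)n2)C1` gives 27200 nM
compound 3 `N#Cc1ccc(Nc2nc(Oc3ccnc4ccccc34)nc(N3CCN(c4cccc(C(F)(F)F)c4)CC3)n2)cc1C(F)(F)F` gives 38700 nM

Among these three numbers compound 3 holds the second highest. Its nearest neighbour is compound 2, whose number lies within the scatter of that of compound 3, so the two cannot be told apart. Compound 1 lies further off: the step of a 2.4-fold lower number from compound 1 to compound 3 (0.38 log units; beyond the scatter) is the only one beyond the scatter in this set.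

Compound 4 `CC(C)N1CCN(c2nc(Nc3ccc(C#N)c(C(F)(F)F)c3)nc(Oc3ccnc4ccccc34)n2)CC1` differs from compound 3 in one place: isopropyl in place of 3-(trifluoromethyl)phenyl on an amine nitrogen in a ring. Going by the values given here, only one measured step touches the same ring nitrogen, a 2.4-fold lower number from compound 1 to compound 3 (0.38 log units; beyond the scatter), and that step swapped one aromatic group for another rather than removing the aromatic group altogether. Among the compounds with values here, no measured step replaces the aromatic group with a short chain. Compound 2, which carries no aromatic group on its ring, sits within the scatter of compound 3, which argues against a large shift in either direction.

The step of a 1.1-fold lower number from compound 3 to compound 4 (0.04 log units; within the scatter) is therefore expected to stay small. Compound 4 is estimated at 35000 nM, with a range from 10000 nM to 120000 nM.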

Compound 4, concentration for 50% growth inhibition: > 100000 nM
Compound 4: only a limit was reported; the forecaster's own chance of this, stated with the estimate: 10%; at least 2.8-fold (0.45 log units) between middle value and limit.
By their numbers in this assay, from the lowest: compounds 2 and 3 (each within the scatter of the next); then compound 1. At a limit, above all of these: compound 4.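

In this assay, compound 4 carries only a limit of the assay, not a number: the limit of > 100000 nM in this assay, at which 1 of the 4 values shown sits. The earlier swap of one aromatic group for another did not show what happens when the aromatic ring on this amine nitrogen goes; isopropyl in place of 3-(trifluoromethyl)phenyl on this amine nitrogen gives an at least 2.5-fold higher number from compound 3 to compound 4 (0.41 log units; beyond the scatter) and so weakens growth inhibition. Lacking an aromatic group does not by itself set the number, since the change to 4-isopropylpiperazin-1-yl from 3,5-dimethylpiperidin-1-yl gives an at least 3.6-fold higher number from compound 2 to compound 4 (0.56 log units; beyond the scatter) even though neither compound has an aromatic group there.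

The data give an at least 1.0-fold higher number from compound 1 to compound 4 (0.03 log units; that floor lies within the scatter), so no difference can be read from this step. Still open, on these data alone, is how a benzyl group, a longer chain such as n-butyl, or a carboxylic acid on the same ring nitrogen would compare with isopropyl and 3-(trifluoromethyl)phenyl.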